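Side-chain amine variation against human topoisomerase 1

The compounds below may be only part of what the source reports. "The series", "measured", "known", "first", "only" and "open" are said of these compounds alone.

Measured so far:
Compound 1, `CNCCCNc1c(F)cc2c(=O)c(C(=O)O)cn(Cc3ccc(-c4ccccc4)cc3)c2c1OC`, gives 101000 nM in an assay on isolated protein for inhibition of DNA topoisomerase 1 (Homo sapiens), with a stated time of 15 min; a higher number here means a weaker inhibitor, a lower number a stronger inhibitor.
Compound 2, `COc1c(N2CC[C@@H](C(N)=O)C2)c(F)cc2c(=O)c(C(=O)O)cn(Cc3ccc(-c4ccccc4)cc3)c12`, gives only a limit in this assay, > 200000 nM.

Compound 2 stands at the limit of > 200000 nM in this assay, at which 1 of the 2 values shown sits, so its position is known only as a limit and not as a number. Among the compounds with values here, the one measured step, an at least 1.9-fold higher number from compound 1 to compound 2 (0.29 log units; that floor lies within the scatter), runs from a compound with a (3-(methylamino)propyl)amino group to one with a 3-carbamoylpyrrolidin-1-yl group.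

Compound 3, `CNCCCCNc1c(F)cc2c(=O)c(C(=O)O)cn(Cc3ccc(-c4ccccc4)cc3)c2c1OC`, is not yet measured. It differs from compound 2 as follows: (4-(methylamino)butyl)amino in place of 3-carbamoylpyrrolidin-1-yl on an aromatic carbon. This change restores an open aminoalkylamino chain of the kind carried by compound 1, one methylene longer, and reverses the direction of the measured step. A lower number for compound 3 than for compound 2 is therefore expected, of a size comparable to that step, because compound 1 gives 101000 nM with the closely related shorter chain. The expected step is an at least 2.0-fold lower number from compound 2 to compound 3 (0.30 log units; that floor lies within the scatter). Compound 3 is estimated at 100000 nM, with a range of 40000 nM to 200000 nM.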

Compound 3, half-maximal inhibitory concentration: > 200000 nM
Compound 3 gave a limit, no number; the forecaster's own chance of this, stated with the estimate: 35%; middle value at least 2.0-fold (0.30 log units) away from the limit.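

Moving from (3-(methylamino)propyl)amino to (4-(methylamino)butyl)amino, one methylene longer, does not yield a readable number in this assay: compound 3 gives only a limit, > 200000 nM. Against the shorter chain, this change gives an at least 1.9-fold higher number from compound 1 to compound 3 (0.29 log units; that floor lies within the scatter), so the longer chain is not shown to weaken inhibition beyond the scatter, although the true gap could be larger. Compound 2 and compound 3 both give limits, so the step between them cannot be read, and an open aminoalkylamino chain cannot be ranked against 3-carbamoylpyrrolidin-1-yl at this position; the upper end of the assay now holds most of the series: the limit of > 200000 nM in this assay, at which 2 of the 3 values shown sit.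

Within the data shown here, compound 1 remains the only compound in this set with a measured number, 101000 nM, so no relationship between chain length and inhibition can be drawn from it alone. Open questions are whether a shorter chain such as (2-(methylamino)ethyl)amino, or a primary amine at the end of the propyl chain, would give a number on the readable side of the limit, and how far such a number would lie from that of compound 1.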